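Nitrile in place of ethylcarbamoyl on the ring carbon

The source may hold more compounds than are shown below. What is called first, only, known or untested is meant among the compounds shown, and "the series" means these compounds.

Measured in a functional assay for inhibition of nuclear factor NF-kappa-B complex (Homo sapiens); on this read-out lower numbers stand for stronger inhibition and higher numbers for weaker inhibition:
compound 1, `COc1ccc2c(c1)OC(c1cc(OC)c(OC)c(OC)c1)C(C(=O)O)=C2`: > 50000 nM, a limit of the assay.
compound 2, `COc1ccc2c(c1)OC(c1cc(OC)c(OC)c(OC)c1)C(C(N)=O)=C2`: > 50000 nM, a limit of the assay.
compound 3, `CCNC(=O)C1=Cc2ccc(OC)cc2OC1c1cc(OC)c(OC)c(OC)c1`: > 50000 nM, a limit of the assay.

Compound 3 stands at the same limit as the other two measured compounds, (the limit of > 50000 nM in this assay, at which 3 of the 3 values shown sit); no numbered value exists anywhere in the set. The steps a step that the two limits leave unreadable from compound 1 to compound 2, a step that the two limits leave unreadable from compound 1 to compound 3 and a step that the two limits leave unreadable from compound 2 to compound 3 are for that reason of unknown size and direction. Compound 4, `COc1ccc2c(c1)OC(c1cc(OC)c(OC)c(OC)c1)C(C#N)=C2`, is not yet measured. It differs from compound 3 by cyano in place of ethylcarbamoyl on a double-bonded ring carbon. For the measured compounds named here, none of the measured steps exchanges the same pair of groups, and all of them begin and end at the limit, so nothing about the size or direction of this change can be read from them in this assay. Compound 4 is therefore expected at 60000 nM, with a range from 15000 nM to 250000 nM, and most probably reported again as a limit rather than a number. The expected step from compound 3 is a step that the limit leaves unreadable from compound 3 to compound 4, which means no readable change is anticipated.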

Compound 4, half-maximal inhibitory concentration: 3400 nM
Compound 4: the middle estimate sits 18-fold (1.25 log units) above what was measured, outside the stated range (below it).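

In this assay the double-bonded ring carbon proves to be a place where a single exchange moves the series off the limit shared by the other compounds: the limit of > 50000 nM in this assay, at which 3 of the 4 values shown sit.

Cyano in place of ethylcarbamoyl gives an at least 14-fold lower number from compound 3 to compound 4 (1.16 log units; beyond the scatter), cyano in place of carbamoyl gives an at least 14-fold lower number from compound 2 to compound 4 (1.16 log units; beyond the scatter), and cyano in place of carboxy gives an at least 14-fold lower number from compound 1 to compound 4 (1.16 log units; beyond the scatter). Each of these steps starts from a limit and so gives only a minimum size, while the steps among compound 1, compound 2 and compound 3 cannot be read.

On these data alone, whether a methyl ester, an aminomethyl group or a bare hydrogen on this carbon would also leave the limit stays open, so the change cannot yet be tied to cyano itself. Also open, as far as these compounds go, is whether cyano keeps this effect when the other groups on the shared core change.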